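A chlorophenyl swap on compound 3

The compounds below may be only part of what the source reports. "The series", "measured", "known", "first", "only" and "open" are said of these compounds alone.

In a functional assay on MCF7 cells (Homo sapiens) for inhibition, read by fluorescence, with a stated time of 72 h (on this read-out higher numbers stand for weaker inhibition of growth and lower numbers for stronger inhibition of growth), the measured compounds read as follows:
Compound 1 `CC(C)CCn1cnc2c(Nc3ccc(Cl)cc3)nc(N[C@H]3CC[C@H](N)CC3)nc21` gives 2700 nM
Compound 2 `COc1ccc(Cn2cnc3c(Nc4cccc(Cl)c4)nc(N[C@H]4CC[C@H](N)CC4)nc32)cc1` gives 4800 nM
Compound 3 `COc1cc(Nc2nc(N[C@H]3CC[C@H](N)CC3)nc3c2ncn3CCC(C)C)cc(OC)c1` gives 4500 nM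

Compound 3 lies within the usual scatter of both other compounds, so it holds no firm rank. Compound 4 `CC(C)CCn1cnc2c(Nc3cccc(Cl)c3)nc(N[C@H]3CC[C@H](N)CC3)nc21` carries 3-chlorophenyl in place of 3,5-dimethoxyphenyl on a nitrogen on an aromatic ring and otherwise matches compound 3. The nearest measured step, with 3,5-dimethoxyphenyl in place of 4-chlorophenyl, is a 1.7-fold higher number from compound 1 to compound 3 (0.22 log units; within the scatter) and gives no firm direction. Compound 2 also carries 3-chlorophenyl but differs elsewhere, so it is only a loose guide. No change beyond the scatter is expected, and the expected shift is a 1.3-fold lower number from compound 3 to compound 4 (0.11 log units; within the scatter) in this assay overall. For compound 4 the estimate is 3500 nM (expected range from 1800 nM to 7000 nM).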

Compound 4, concentration for 50% growth inhibition: 2100 nM
Estimate against measurement, compound 4: 1.7-fold (0.22 log units) above, within the range that was stated.
By their numbers in this assay, from the lowest: compounds 4, 1, 3 and 2 (each within the scatter of the next, the first and the last beyond it).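

Swapping 3,5-dimethoxyphenyl for 3-chlorophenyl on a nitrogen on an aromatic ring gives the first step at this position beyond the scatter in this assay (a 2.1-fold lower number from compound 3 to compound 4 (0.33 log units; beyond the scatter)), though a modest one. Against that, 3-chlorophenyl in place of 4-chlorophenyl stays within the scatter (a 1.3-fold lower number from compound 1 to compound 4 (0.11 log units; within the scatter)), so the two chlorophenyl groups cannot be told apart here. On the saturated chain carbon bound to an aromatic nitrogen, isobutyl in place of 4-methoxyphenyl also gives a modest step beyond the scatter (a 2.3-fold lower number from compound 2 to compound 4 (0.36 log units; beyond the scatter)). Still open, from the compounds shown here alone, is how a phenyl group carrying an amine or a carboxylic acid would read on this nitrogen. Nothing available explains any of these steps.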